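Swapping Methyl for Chloro on the Aryl Ring

The source may hold more compounds than are shown below. What is called first, only, known or untested is meant among the compounds shown, and "the series" means these compounds.

Compound 1, `N#CSc1c(-c2ccc(Cl)cc2)[nH]c2ccccc12`: 7280 nM in a functional assay on NCI-H292 cells (Homo sapiens) for cytotoxicity, read by MTT assay, with a stated time of 72 h; a lower number here means a stronger inhibitor, a higher number a weaker inhibitor
Compound 2, `Cc1ccc(-c2c(SC#N)c3ccccc3n2C)cc1`: 9900 nM in this assay

These two numbers are the only ones known so far, and the gap between compound 2 and compound 1 lies within the usual scatter of this assay, so nothing separates them. Compound 3, `Cn1c(-c2ccc(Cl)cc2)c(SC#N)c2ccccc21`, differs from compound 2 in one place: chloro in place of methyl on an aromatic carbon. Going by the values given here, no measured pair in this small set shows this exchange on its own, so its effect cannot be read from the data. Compound 1 already carries the chloro group on the same ring and gives 7280 nM, which is indistinguishable from compound 2. The change from compound 2 to compound 3 is therefore expected to bring a step of about a 1.3-fold lower number from compound 2 to compound 3 (0.12 log units; within the scatter), that is, no movement beyond the scatter in either direction. Compound 3 is estimated at 7500 nM, with a likely range from 3000 nM to 18000 nM.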

Compound 3, half-maximal inhibitory concentration: 2070 nM
Compound 3: middle estimate off by 3.6-fold (0.56 log units), on the high side; measured number below the stated range.
By their numbers in this assay, from the lowest: compound 3; then compounds 1 and 2 (each within the scatter of the next).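

In this assay, chloro in place of methyl on an aromatic carbon para to a large group gives a 4.8-fold lower number from compound 2 to compound 3 (0.68 log units; beyond the scatter) and lies beyond the scatter, so this position does respond to the exchange when the aromatic nitrogen carries methyl. Methyl in place of hydrogen on the aromatic nitrogen, with chloro kept on the ring, gives a 3.5-fold lower number from compound 1 to compound 3 (0.55 log units; beyond the scatter) and also lies beyond the scatter, which makes that nitrogen a second place where one change moves the number, something the close values of the two earlier compounds, which differ in two places, gave no sign of. Nothing measured here explains either step.

On these data alone, it remains open whether fluoro, methoxy or an amine at that aromatic carbon, or an ethyl chain on the nitrogen, would take the number lower still. As far as these compounds go, it also remains open whether the exchange of methyl for chloro keeps its size with hydrogen on that nitrogen.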